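Propargyl for benzyl on the core nitrogen: series notes

The source may report more compounds than this note shows. Statements on the series, on what has been measured and on what is new or still open speak of the compounds shown alone.

Of the compounds shown here, three of the shared core have been measured in an assay on isolated protein for inhibition of Aromatase (Homo sapiens), read by fluorescence, using NADPH, with a stated time of 30 min, tested at 50 uM; on this read-out lower numbers stand for less inhibition and higher numbers for more inhibition at the one concentration tested (going by the name of the read-out). Compound 1 `c1ccc(Cn2c(-c3ccccc3)cc3ccccc32)cc1` gives 0%, the lowest of the three numbers. Compound 3 `Clc1ccc(-c2cc3ccccc3[nH]2)cc1Cl` gives 22.7%, a number above that of compound 1 by a margin that lies beyond the scatter. Compound 2 `Cn1c(-c2ccccc2)cc2cc([N+](=O)[O-])ccc21` gives 77%, the highest of the three, and its distance from compound 1 is also beyond the scatter. No two of these compounds differ in only one place, so nothing can be said of any single structural change from the measured numbers alone.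

Within the data shown here, compound 4 `C#CCn1c(-c2ccccc2)cc2ccccc21` is the one compound not yet measured. It differs from compound 1 as follows: ethynyl in place of phenyl on a saturated chain carbon bound to an aromatic nitrogen. Among the measured compounds shown here, compound 1 itself shows no inhibition in this assay, so there is no downward room, and the data give no measured step that would suggest how a change on the saturated chain carbon bound to the aromatic nitrogen moves the read-out. The step of a number 8 percentage points higher from compound 1 to compound 4 (within the scatter) is expected to be small and upward, within the usual scatter. Compound 4 is therefore expected to give 8% in this assay, with a range from 0% to 30%, because compound 1 gives 0% and the change is a modest one.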

Compound 4, a percentage reported as inhibition, at one concentration (the size of the read-out at that concentration, not a potency): 26.3%
The estimate for compound 4 lay 18.3 percentage points below the measured number, within the range that was stated.
By their numbers in this assay, from the lowest: compound 1; then compounds 3 and 4 (each within the scatter of the next); then compound 2.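

Propargyl for benzyl on the core nitrogen, read in this assay, gives the first single-place step in the series: a number 26.3 percentage points higher from compound 1 to compound 4 (beyond the scatter). Among these compounds, the read-out at this position therefore responds to the group it carries, which the earlier compounds could not show, as no two of them differed in only one place. On an otherwise unchanged core, replacing phenyl with ethynyl on a saturated chain carbon bound to an aromatic nitrogen removes the six-membered aromatic ring, introduces a triple bond outside aromatic rings, and separates a compound with no inhibition at the one concentration tested from one with inhibition beyond the scatter. Nothing at hand bears on why the read-out moves with this change.

From the compounds shown here alone, whether the rise depends on the triple bond or would also appear with a propyl chain, an allyl group or a plain hydrogen on the aromatic nitrogen remains open. Also open, going by these compounds, is whether the same exchange would move the read-out in the same direction on a core carrying the nitro group of compound 2.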